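Swapping one side chain on an amide-type nitrogen

A few compounds are considered here, and "the series" means these few. Any claim that something is new, unique, unknown or untested is made for them only; others in the source may bear on it.

Values in a physicochemical assay for solubility, in phosphate buffer, at pH 6.5 (a higher number here means a more soluble compound, a lower number a less soluble compound), so far
Compound 1 `C=C[C@@H]1C[C@]1(NC(=O)[C@@H]1C[C@@H](Oc2nccc3cc(OC)ccc23)CN1C(=O)[C@@H](NC(=O)N[C@H](COC)[C@@H](C)CC)C(C)(C)C)C(=O)NS(=O)(=O)C1CC1` gives 326 ug/mL
Compound 2 `C=C[C@@H]1C[C@]1(NC(=O)[C@@H]1C[C@@H](Oc2nccc3cc(OC)ccc23)CN1C(=O)[C@@H](NC(=O)N[C@H](COC)CC(C)C)C(C)(C)C)C(=O)NS(=O)(=O)C1CC1` gives 225 ug/mL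

Compound 2 cannot be separated from compound 1 on these numbers (a 1.4-fold lower number from compound 1 to compound 2 (0.16 log units; within the scatter)). Compound 3 `C=C[C@@H]1C[C@]1(NC(=O)[C@@H]1C[C@@H](Oc2nccc3cc(OC)ccc23)CN1C(=O)[C@@H](NC(=O)N[C@H](C(=O)OC)C(C)(C)C)C(C)(C)C)C(=O)NS(=O)(=O)C1CC1` differs from compound 2 on an amide-type nitrogen (1-(methoxycarbonyl)-2,2-dimethylpropyl in place of 1-(methoxymethyl)-3-methylbutyl on an amide-type nitrogen). There, 1-(methoxycarbonyl)-2,2-dimethylpropyl takes the place of 1-(methoxymethyl)-3-methylbutyl. Going by the values given here, only the single measured step bears on this change, and only loosely. Among the compounds with values here, it exchanged isobutyl for sec-butyl and stayed within the scatter, and no measured compound carries a methoxycarbonyl group. The data therefore point in no direction, and no step beyond the scatter is expected in this assay for this change. The expected step is a 1.2-fold lower number from compound 2 to compound 3 (0.07 log units; within the scatter) as an estimate with wide uncertainty. For compound 3 the estimated value is 190 ug/mL (expected range 70 ug/mL to 450 ug/mL).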

Compound 3, solubility: 754 ug/mL
Estimate against measurement, compound 3: 4.0-fold (0.60 log units) below, outside the stated range (above it).
By their numbers in this assay, from the lowest: compounds 2 and 1 (each within the scatter of the next); then compound 3.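

In this assay, placing 1-(methoxycarbonyl)-2,2-dimethylpropyl on the amide-type nitrogen gives a 3.4-fold higher number from compound 2 to compound 3 (0.53 log units; beyond the scatter) and a 2.3-fold higher number from compound 1 to compound 3 (0.36 log units; beyond the scatter). This position can therefore produce a step beyond the scatter, which the exchange of isobutyl for sec-butyl did not show, and compound 3 stands above both earlier compounds. Nothing available here explains the rise.

The new group differs from the earlier ones in two parts at once, the methoxycarbonyl and the 2,2-dimethylpropyl chain, and these compounds do not show which part carries the step. On these data alone, it also remains open how a carboxylic acid or a primary amide in place of the methoxycarbonyl would read in this assay.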